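The compounds below may be only part of what the source reports. "The series", "measured", "known", "first", "only" and "open" are said of these compounds alone.

Working notes on the series

Two members of the series have been run so far in a functional assay on feces (Oryctolagus cuniculus); on this read-out lower numbers stand for stronger inhibition and higher numbers for weaker inhibition. Compound 1 `O=C1NC(=O)C([C@H]2C[C@H](O)[C@@H](CO)O2)C=C1I` gives 1 ug/mL in this assay. Compound 2 `O=c1[nH]c(=O)n([C@H]2C[C@H](O)[C@@H](CO)O2)cc1C1SCCS1` gives 100 ug/mL in this assay, the higher of the two numbers recorded, and the gap between compound 1 and compound 2 lies well beyond the usual scatter of repeated measurements. Among the compounds with values here, no step between two measured compounds that differ in only one place is available, so the dependence of this read-out on the substituent on the aromatic carbon rests on these two points alone.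

Compound 3 `O=c1[nH]c(=O)n([C@H]2C[C@H](O)[C@@H](CO)O2)cc1/C=N/O` is the next member to be run. Compound 3 differs from compound 2 as follows: a group of 3 heavy atoms (1 carbon, 1 nitrogen, 1 oxygen; no ring) in place of a group of 5 heavy atoms (3 carbon, 2 sulfur; one five-membered non-aromatic ring with 2 hetero atoms), on an aromatic carbon. Within the data shown here, nothing measured so far tells how this particular exchange on the shared core acts in this assay; compound 1 carries yet another group at that position and does not bridge the gap.

On these two points the expectation for compound 3 is a moderate move toward a lower number, a step of a 3.3-fold lower number from compound 2 to compound 3 (0.52 log units; beyond the scatter) in this assay. Compound 3 is thus estimated at 30 ug/mL in this assay, with a range from 5 ug/mL to 150 ug/mL.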

Compound 3, concentration for 50% inhibition: 300 ug/mL
Estimate against measurement, compound 3: 10-fold (1.00 log units) below; measured number above the stated range.
By their numbers in this assay, from the lowest: compound 1; then compound 2; then compound 3.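

Within the data shown here, this is the first step that changes a single place on the shared core, and in this assay it goes toward weaker inhibition: the group of 3 heavy atoms with no ring, in place of the five-membered non-aromatic ring with 2 hetero atoms on the aromatic carbon, gives a 3.0-fold higher number from compound 2 to compound 3 (0.48 log units; beyond the scatter) and counts as a modest change. The read-out at this position therefore responds to the exchange of one group for the other, and on this pair the ring-free group with 1 hydrogen-bond donor does not improve on the ring carrying 2 sulfur atoms. No measurement at hand accounts for the direction of this step.

Among these compounds, with only this pair, the ring and the donor cannot be separated as the source of the step, and compound 1 differs from both compounds in more than one place, so it does not help to settle this. Also open, going by these compounds, is how an amine, a carboxylic acid or a longer chain on this same aromatic carbon would read in this assay on the core shared by compound 2 and compound 3.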